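A few compounds are considered here, and "the series" means these few. Any claim that something is new, unique, unknown or untested is made for them only; others in the source may bear on it.

Measured in a functional assay on Jurkat cells (Homo sapiens) for cytotoxicity, read by luminescence and CellTiter-Glo, with a stated time of 3 days; a lower number here means a stronger inhibitor, a higher number a weaker inhibitor:

- compound 1 `O=C(Nc1cc(C(F)(F)F)cc(C(F)(F)F)c1)c1cc(Cl)c(F)cc1O`: 730 nM
- compound 2 `N#Cc1ccc(NC(=O)c2ccc(Br)cc2O)c(Cl)c1`: 750 nM
- compound 3 `O=C(Nc1cc(C(F)(F)F)cc(C(F)(F)F)c1)c1ccc(Br)cc1O`: 930 nM

Compound 1 stands level with the other two, as all three numbers lie within the scatter of repeated measurements. Compound 4 `O=C(Nc1cc(C(F)(F)F)cc(C(F)(F)F)c1)c1cc(Br)c(F)cc1O` has not yet been measured. It differs from compound 1 by bromo in place of chloro on an aromatic carbon, ortho to a fluoro group and para to a hydroxy group: bromo in place of chloro on an aromatic carbon. Within the data shown here, no measured pair isolates this swap, but compound 3, which also carries bromo, gives 930 nM. No step beyond the scatter is therefore expected in this assay. The estimated change is a 1.0-fold lower number from compound 1 to compound 4 (0.01 log units; within the scatter). For compound 4 the expected value is 720 nM, with an estimated range from 360 nM to 1400 nM.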

Compound 4, half-maximal inhibitory concentration: 700 nM
The estimate for compound 4 lay 1.0-fold (0.01 log units) above the measured number; the range from low to high includes it.
By their numbers in this assay, from the lowest: compounds 4, 1, 2 and 3 (each within the scatter of the next).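

In this assay, bromo in place of chloro on this aromatic carbon, ortho to a fluoro group and para to a hydroxy group, gives a 1.0-fold lower number from compound 1 to compound 4 (0.02 log units; within the scatter), so the two halogens cannot be told apart here. Among these compounds, this pair isolates the swap directly, which the earlier compounds could not do. Nothing at hand offers a reason for this result.

Still open, as far as these compounds go, is whether an amine, a methoxy group or a carboxylic acid on this carbon would shift the number beyond the scatter. Also open, from the compounds shown here alone, is how much the neighbouring fluoro group contributes.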